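From benzylamino to 4-methylpiperazin-1-yl in compound 3

The source may report more compounds than this note shows. Statements on the series, on what has been measured and on what is new or still open speak of the compounds shown alone.

Compounds tested in a functional assay on NCI-H460 cells (Homo sapiens) for antiproliferative activity, read by CCK-8 assay, with a stated time of 72 h; on this read-out lower numbers stand for stronger inhibition and higher numbers for weaker inhibition:
- compound 1 `Nc1ccccc1NC(=O)c1ccc(Cn2cnc3c(NCc4ccccc4)nc(Cl)nc32)cc1`: 11200 nM
- compound 2 `Nc1ccccc1NC(=O)c1ccc(Cn2cnc3c(Nc4ccc(-c5ccccn5)cc4)nc(Cl)nc32)cc1`: 18400 nM
- compound 3 `CN1CCN(c2nc(Cl)nc3c2ncn3Cc2ccc(C(=O)Nc3ccccc3N)cc2)CC1`: not yet measured

Going by the values given here, compound 1 sits level with compound 2, its only measured neighbour, since the two values lie within the usual scatter of each other. Compound 3 keeps the core of compound 1 but changes one group: 4-methylpiperazin-1-yl in place of benzylamino on an aromatic carbon. The new group, 4-methylpiperazin-1-yl, replaces benzylamino on an aromatic carbon, next to the ring nitrogen. Among the compounds with values here, only one measured step bears on this. It is a 1.6-fold higher number from compound 1 to compound 2 (0.22 log units; within the scatter), a swap of benzyl for 4-(pyridin-2-yl)phenyl on a nitrogen on an aromatic ring, and it stays within the scatter. Within the data shown here, no measured compound carries 4-methylpiperazin-1-yl, which leaves the expectation uncertain. No change beyond the scatter is expected in this assay, in either direction. The estimated step is a 1.1-fold higher number from compound 1 to compound 3 (0.03 log units; within the scatter). For compound 3 the expected value is 12000 nM, with an estimated range of 4500 nM to 30000 nM.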

Compound 3, half-maximal inhibitory concentration: 6160 nM
Compound 3: middle estimate off by 1.9-fold (0.29 log units), on the high side, and the stated range covers the measured number.
By their numbers in this assay, from the lowest: compounds 3, 1 and 2 (each within the scatter of the next, the first and the last beyond it).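

In this assay, putting 4-methylpiperazin-1-yl in place of benzylamino gives a 1.8-fold lower number from compound 1 to compound 3 (0.26 log units; within the scatter) and so stays level with the parent. The earlier step changed only the group carried on the amine nitrogen, whereas this one replaces the whole substituent on the aromatic carbon, taking away the six-membered aromatic ring of carbon and the hydrogen-bond donor of benzylamino. In this pair, therefore, neither feature is needed to keep the read-out at this level, and no measurement here explains the result.

Going by these compounds, it remains open whether morpholin-4-yl or piperazin-1-yl, which lacks the methyl, would read the same on this carbon. On these data alone, all three compounds also keep the chloro group, so the effect of an amine in its place is unknown.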